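Sulfonamide substituent trimmed in a pyrimidine-fused lactam series

The source may hold more compounds than are shown below. What is called first, only, known or untested is meant among the compounds shown, and "the series" means these compounds.

Three compounds of the shared core carry a measurement. Compound 1 `CC[C@@H]1C(=O)N(C)c2cnc(-n3ccc4cc(F)ccc43)nc2N1C1CCCC1` gives 46500 nM in a functional assay on NCI-H1975 cells (Homo sapiens) for antiproliferative activity, read by CCK-8 assay, with a stated time of 72 h; a lower number here means a stronger inhibitor of growth, a higher number a weaker inhibitor of growth. Compound 2 `CC[C@@H]1C(=O)N(C)c2cnc(Nc3ccc(S(=O)(=O)NCCO)cc3)nc2N1C1CCCC1` gives 2100 nM in this assay. Compound 3 `CCCCNS(=O)(=O)c1ccc(Nc2ncc3c(n2)N(c2ccn(C)n2)C(CC)C(=O)N3C)cc1` gives 4120 nM in this assay, the second highest of the three numbers; its gap to compound 2 lies within the scatter, while compound 1 sits beyond the scatter above it. Compounds 2 and 3 differ in more than one place, so no single change can be read from their pair.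

The next compound, compound 4 `CCC1C(=O)N(C)c2cnc(Nc3ccc(S(N)(=O)=O)cc3)nc2N1c1ccn(C)n1`, follows from compound 3 by a change at the sulfonamide: hydrogen in place of butyl on a sulfonamide nitrogen. Among the compounds with values here, no measured pair isolates this change. The two sulfonamide-bearing compounds, compound 2 and compound 3, sit within the scatter of each other despite different groups on the sulfonamide nitrogen, so the step to compound 4 is expected to be small, leaning toward a lower number if anything. Compound 4 is expected to give 3000 nM in this assay, within 1200 nM to 8000 nM, a step of a 1.4-fold lower number from compound 3 to compound 4 (0.14 log units; within the scatter) estimated from compound 3.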

Compound 4, concentration for 50% growth inhibition: "not active" (no number reported)
Compound 4: no number reported; the estimate stays without a comparison.
By their numbers in this assay, from the lowest: compounds 2 and 3 (each within the scatter of the next); then compound 1.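

Within the data shown here, compound 4 is reported as not active in this assay without a number, and no step from compound 3 to compound 4 can be read. No available evidence bears on this result. The compounds shown leave open what size of effect hydrogen in place of butyl on a sulfonamide nitrogen has.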